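The source may report more compounds than this note shows. Statements on the series, on what has been measured and on what is new or still open speak of the compounds shown alone.

Compound 1 `C=C(/C=C/c1ccc(OC)c(N)c1)c1cc(OC)c(OC)c(OC)c1`: 560 nM
Compound 2 `CC=C(/C=C/c1ccc(OC)c(N)c1)c1cc(OC)c(OC)c(OC)c1`: 319 nM

Of the compounds shown here, two have been measured in a functional assay on PC-3 cells (Homo sapiens) for antiproliferative activity, read by MTT assay, with a stated time of 48 h; a lower number here means a stronger inhibitor, a higher number a weaker inhibitor. Compound 2 gives 319 nM, and compound 1 gives 560 nM; the step of a 1.8-fold lower number from compound 1 to compound 2 (0.24 log units; within the scatter) is within the scatter, so the two are not separated by this assay. Compound 3 `CCC=C(/C=C/c1ccc(OC)c(N)c1)c1cc(OC)c(OC)c(OC)c1` has not yet been tested. The change from compound 2 to compound 3 is methyl in place of hydrogen on a saturated chain carbon bound to a double-bonded chain carbon. Among the compounds with values here, the only measured step that bears on it is a 1.8-fold lower number from compound 1 to compound 2 (0.24 log units; within the scatter), which is the same kind of addition made one bond further in; it did not move the number beyond the scatter. On that basis no step beyond the scatter is expected for compound 3 in this assay, neither gain nor loss of note. Compound 3 is therefore estimated at 280 nM, with a range from 120 nM to 650 nM. That expectation amounts to a 1.1-fold lower number from compound 2 to compound 3 (0.06 log units; within the scatter).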

Compound 3, half-maximal inhibitory concentration: 285 nM
Compound 3: the middle estimate sits 1.0-fold (0.01 log units) below what was measured; measured number inside the range.
By their numbers in this assay, from the lowest: compounds 3, 2 and 1 (each within the scatter of the next).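

Going from methyl to ethyl on this chain, by placing methyl in place of hydrogen on a saturated chain carbon bound to a double-bonded chain carbon, does not separate the two compounds in this assay (a 1.1-fold lower number from compound 2 to compound 3 (0.05 log units; within the scatter)). The whole change also stays within the scatter (a 2.0-fold lower number from compound 1 to compound 3 (0.29 log units; within the scatter)), so at this size this position shows no clear gain or loss. Nothing measured here offers an explanation for this flat result.

On these data alone, whether a longer chain such as propyl or butyl, or a branched one such as isopropyl, would move the number beyond the scatter remains open. The same holds for an amine or a carboxylic acid at the end of the chain.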